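Pyridin-2-yl for Fluorophenyl on the Sulfonamide Arm

The compounds below may be only part of what the source reports. "The series", "measured", "known", "first", "only" and "open" are said of these compounds alone.

Three compounds share one core and differ only in the group on a saturated chain carbon bound to a sulfonamide nitrogen. In an assay on isolated protein for inhibition of protein deacetylase HDAC6 (Homo sapiens), read by mobility shift assay (a higher number here means a weaker inhibitor, a lower number a stronger inhibitor), compound 1 `O=C(NO)c1ccc(CN(Cc2ccncc2)S(=O)(=O)c2cc(F)c(F)c(F)c2F)cc1` gives 11 nM. In this assay compound 2 `O=C(NO)c1ccc(CN(Cc2ccc(F)cc2)S(=O)(=O)c2cc(F)c(F)c(F)c2F)cc1` gives 21 nM. In this assay compound 3 `O=C(NO)c1ccc(CN(Cc2cccc(F)c2)S(=O)(=O)c2cc(F)c(F)c(F)c2F)cc1` gives 14 nM, which places compound 3 second highest of the three numbers, nearest to compound 1 and furthest from compound 2, both within the scatter.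

Compound 4 `O=C(NO)c1ccc(CN(Cc2ccccn2)S(=O)(=O)c2cc(F)c(F)c(F)c2F)cc1` carries the change (pyridin-2-yl in place of 3-fluorophenyl on a saturated chain carbon bound to a sulfonamide nitrogen). Within the data shown here, the steps that bear on it are the exchange of pyridin-4-yl for 3-fluorophenyl, a 1.3-fold higher number from compound 1 to compound 3 (0.10 log units; within the scatter), the related 1.9-fold higher number from compound 1 to compound 2 (0.28 log units; within the scatter), and the move between the two fluorophenyl groups, a 1.5-fold lower number from compound 2 to compound 3 (0.18 log units; within the scatter). None of these reaches beyond the scatter, and no compound shown holds pyridin-2-yl itself. The step in this assay from compound 3 to compound 4 is therefore expected to be small, a 1.1-fold lower number from compound 3 to compound 4 (0.03 log units; within the scatter), with no confident direction. Compound 4 is estimated at 13 nM in this assay, within 6 nM to 28 nM.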

Compound 4, half-maximal inhibitory concentration: 6 nM
For compound 4 the middle estimate is 2.2-fold (0.34 log units) above the measured one; measured number inside the range.
By their numbers in this assay, from the lowest: compounds 4, 1, 3 and 2 (each within the scatter of the next, the first and the last beyond it).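

In this assay, among these compounds, every earlier step at this position lay within the scatter, and pyridin-2-yl gives the first steps beyond it, both modest (a 2.3-fold lower number from compound 3 to compound 4 (0.37 log units; beyond the scatter)) and (a 3.5-fold lower number from compound 2 to compound 4 (0.54 log units; beyond the scatter)). Pyridin-2-yl in place of pyridin-4-yl stays within the scatter (a 1.8-fold lower number from compound 1 to compound 4 (0.26 log units; within the scatter)), so the two pyridine-bearing compounds cannot be told apart, yet only compound 4 separates from the fluorophenyl compounds. Nothing available explains the larger steps to pyridin-2-yl.

The compounds shown leave open whether a plain phenyl or pyridin-3-yl would give a number closer to compound 4 or to the fluorophenyl compounds. They also leave open whether a longer chain, 2-(pyridin-2-yl)ethyl in place of (pyridin-2-yl)methyl, would keep the gain over the fluorophenyl compounds.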